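Bromo on a compound at the assay limit

The source may report more compounds than this note shows. Statements on the series, on what has been measured and on what is new or still open speak of the compounds shown alone.

Compound 1 `O=C(COc1ccc(C(=O)/C=C/c2ccc(F)c(F)c2)cc1)N[C@H]1CCOC1=O`: > 64000 nM
Compound 2 `COc1ccccc1/C=C/C(=O)c1ccc(OCC(=O)N[C@H]2CCOC2=O)cc1`: > 64000 nM
Compound 3 `O=C(COc1ccc(C(=O)/C=C/c2ccccc2)cc1)N[C@H]1CCOC1=O`: > 64000 nM

All three results come from a functional assay on MCF7 cells (Homo sapiens) for antiproliferative activity, read by MTT assay, with a stated time of 72 h (on this read-out higher numbers stand for weaker inhibition and lower numbers for stronger inhibition), and each one is a limit, not a number. Compound 3 stands with the other two at the limit of > 64000 nM in this assay, at which 3 of the 3 values shown sit.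

Compound 4 `O=C(COc1ccc(C(=O)/C=C/c2ccccc2Br)cc1)N[C@H]1CCOC1=O` makes one change to compound 3: bromo in place of hydrogen on an aromatic carbon. The bromo sits ortho to a large group.

The closest measured change puts hydrogen in place of methoxy on an aromatic carbon, and it gives a step that the two limits leave unreadable from compound 2 to compound 3. Replacing 3,4-difluorophenyl with phenyl gives a step that the two limits leave unreadable from compound 1 to compound 3. Neither offers a size to carry over.

Compound 2 already carries a methoxy on an aromatic carbon, and its > 64000 nM is a limit. This makes a second limit the likeliest result for compound 4, although a measurable value remains possible. The expected change, a number no higher from compound 3 to compound 4 (the limit leaves the size open), is an estimate with no direction beyond the scatter. For compound 4 the estimated value is 64000 nM, with an expected range from 25000 nM to 100000 nM.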

Compound 4, half-maximal inhibitory concentration: 15300 nM
The estimate for compound 4 lay 4.2-fold (0.62 log units) above the measured number; the measured number lies below the stated range.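

On the aromatic carbon ortho to a large group, bromo in place of hydrogen gives an at least 4.1-fold lower number from compound 3 to compound 4 (0.62 log units; beyond the scatter) in this assay, while the steps among compound 1, compound 2 and compound 3 cannot be read. At this same place, bromo in place of methoxy gives an at least 4.1-fold lower number from compound 2 to compound 4 (0.62 log units; beyond the scatter), and 2-bromophenyl in place of 3,4-difluorophenyl gives an at least 4.1-fold lower number from compound 1 to compound 4 (0.62 log units; beyond the scatter), so among these substituents only bromo brings a measurable number. Compound 4 is the only one of the four with such a number, and the other three remain at a limit: the limit of > 64000 nM in this assay, at which 3 of the 4 values shown sit.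

From the compounds shown here alone, whether this result is specific to bromo stays open, and chloro, an amine or a carboxylic acid on this aromatic carbon would test it. Going by these compounds, the full size of each step also stays unknown, with only limits at its starting end.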